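Swapping an ether chain for a pentenyl chain

This account rests on a few compounds, and the source may have more. Where it says the series, first, only, none or still open, it means among the compounds named here.

Compound 2 `COc1cc(Cc2nc3c(N)nc(F)nc3n2CCOC(C)C)cc(OC)c1OC` carries the isopropoxyethyl chain on the shared core. In a functional assay on MCF7 cells (Homo sapiens) for cytotoxicity (a higher number here means that more compound is needed for the effect, a lower number that less compound is needed), compound 2 gives 769000000 nM, the higher of the two numbers measured. Compound 1 `CCCCn1c(Cc2cc(OC)c(OC)c(OC)c2)nc2c(N)nc(F)nc21`, with a butyl chain, gives 185000000 nM in this assay; the step of a 4.2-fold higher number from compound 1 to compound 2 (0.62 log units; beyond the scatter) is the only one measured. Compound 3 `C=CCCCn1c(Cc2cc(OC)c(OC)c(OC)c2)nc2c(N)nc(F)nc21` differs from compound 2 by allyl in place of isopropoxy on a saturated chain carbon, two bonds along the chain from an aromatic nitrogen. That change returns the chain to an all-carbon chain like that of compound 1, so a partial reversal of a 4.2-fold higher number from compound 1 to compound 2 (0.62 log units; beyond the scatter) is expected, namely a 3.5-fold lower number from compound 2 to compound 3 (0.54 log units; beyond the scatter). Compound 3 is therefore estimated at 220000000 nM, within 70000000 nM to 700000000 nM.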

Compound 3, half-maximal effective concentration: 55600000 nM
Compound 3: middle estimate off by 4.0-fold (0.60 log units), on the high side; measured number outside the range, below it.
By their numbers in this assay, from the lowest: compound 3; then compound 1; then compound 2.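

Compound 3 shows that the all-carbon chains at this position do not behave alike in this assay and that the change goes further than a return to compound 1. The move to the pent-4-en-1-yl chain gives a 14-fold lower number from compound 2 to compound 3 (1.14 log units; beyond the scatter) and also a 3.3-fold lower number from compound 1 to compound 3 (0.52 log units; beyond the scatter) so this chain has the lowest number of the three. The compounds shown leave open whether the double bond or the extra chain length goes with the lower number, which a saturated pentyl chain would separate, and how a terminal amine would compare. No available evidence gives a reason for these steps.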